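The compounds below may be only part of what the source reports. "The series", "measured", "known", "first", "only" and "open" are said of these compounds alone.

Compound 1 `Cn1c(-c2ccccc2)cnc1NC(=O)c1cc(-c2ccccn2)[nH]n1`: in a toxicity assay on THP-1 cells (Homo sapiens) for inhibition (on this read-out higher numbers stand for lower toxicity in this test and lower numbers for higher toxicity in this test), compound 1 reaches > 50000 nM, which is a limit of the assay and not a number.
Compound 2 `COc1ccc(-c2cnc(NC(=O)c3cccc([N+](=O)[O-])c3)n2C)cc1`: compound 2 reaches > 100000 nM, again a limit of the assay.
Compound 3 `CCCn1c(-c2ccc(OC)cc2)cnc1NC(=O)c1ccc(F)cc1`: compound 3 reaches > 100000 nM, also a limit.

Compound 2 stands at the limit of > 100000 nM in this assay, at which 2 of the 3 values shown sit. Compound 1 stands at the limit of > 50000 nM in this assay, at which 1 of the 3 values shown sits. Among the compounds with values here, none of the three compounds shows measurable toxicity within the tested range, so no step between measured compounds can be drawn.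

Compound 4 `COc1ccc(-c2cnc(NC(=O)c3cccc(C)c3)n2C)cc1` differs from compound 2 by methyl in place of nitro on an aromatic carbon. With compound 2 at a limit, the expected step in this assay is a number no higher from compound 2 to compound 4 (the limit leaves the size open), none beyond the scatter. Compound 4 is therefore expected to sit around 100000 nM, with a range from 50000 nM to 300000 nM, most likely again reported only as a limit.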

Compound 4, half-maximal cytotoxic concentration: > 100000 nM
Compound 4: no number, only a limit; the forecaster's own chance of this, stated with the estimate: 85%; the middle value sits exactly at the limit.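

Compound 2 and compound 4 both give only a limit of the assay, so no step can be read between them. The compounds shown leave open whether methyl in place of nitro changes the result in this assay at all.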